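A Fluorine on the Pendant Phenyl Ring: Solubility Outlook

The source may report more compounds than this note shows. Statements on the series, on what has been measured and on what is new or still open speak of the compounds shown alone.

Compound 3 `COc1cccc(CNCCCNc2ccnc3cc(-c4ccccc4)ccc23)c1O` gives the highest of the three measurements in a physicochemical assay for solubility, with a stated time of 18 h, at pH 7.4 (a higher number here means a more soluble compound, a lower number a less soluble compound), at 32000 nM. Compound 1 `COc1cccc(CNCCCNc2ccnc3cc(Cc4ccccc4)ccc23)c1O` gives 4200 nM and compound 2 `CCC(CC)c1ccc2c(NCCCNCc3cccc(OC)c3O)ccnc2c1` gives 4200 nM; the steps of a 7.6-fold higher number from compound 1 to compound 3 (0.88 log units; beyond the scatter) and a 7.6-fold higher number from compound 2 to compound 3 (0.88 log units; beyond the scatter) set compound 3 apart from both. Compound 4 `COc1cccc(CNCCCNc2ccnc3cc(-c4ccc(F)cc4)ccc23)c1O` differs from compound 3 in one place: fluoro in place of hydrogen on an aromatic carbon. Among the compounds with values here, no measured step exchanges hydrogen for fluoro, so the two steps toward compound 3, which replace benzyl and pentan-3-yl by phenyl, bear on it only by showing the scale of change seen. The step from compound 3 to compound 4 is expected to be small, a 1.6-fold lower number from compound 3 to compound 4 (0.20 log units; within the scatter), probably slightly downward. Compound 4 is therefore expected to give about 20000 nM, within 7000 nM to 55000 nM.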

Compound 4, solubility: 32000 nM
Estimate against measurement, compound 4: 1.6-fold (0.20 log units) below; measured number inside the range.
By their numbers in this assay, from the lowest: compounds 1 and 2 (each within the scatter of the next); then compounds 3 and 4 (each within the scatter of the next).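

In this assay, fluoro in place of hydrogen, on an aromatic carbon para to a large group, is the only change shown on the phenyl ring, and it leaves the number where it was (no change at the digits printed from compound 3 to compound 4 (within the scatter)). Compound 4 therefore keeps the same distance from the two compounds without a directly attached phenyl (a 7.6-fold higher number from compound 1 to compound 4 (0.88 log units; beyond the scatter) and a 7.6-fold higher number from compound 2 to compound 4 (0.88 log units; beyond the scatter)). Nothing measured here accounts for this result.

The compounds shown leave open whether an amine or a carboxylic acid at this place would also leave the number unchanged, and whether fluoro on another carbon of the ring would do the same.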